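The compounds below may be only part of what the source reports. "The series", "measured", "known", "first", "only" and "open" are said of these compounds alone.

Working notes on the series. Compound 2 `Cc1ccc(Nc2cc(-c3ccccc3)oc(=O)c2)cc1` gives 0.09 uM in a functional assay on SK-BR-3 cells (Homo sapiens) for cytotoxicity, read by MTT assay, with a stated time of 72 h (a lower number here means that less compound is needed, a higher number that more compound is needed for the effect), and holds the lowest number among the two values shown. Compound 1 `COc1cccc(Nc2cc(-c3ccccc3)oc(=O)c2)c1` sits at a higher number, 0.74 uM, a gap beyond the scatter. Compound 3 `COc1ccc(Nc2cc(C(C)C)oc(=O)c2)cc1` reaches only the limit > 30 uM in this assay, so no number is known for it (the limit of > 30 uM in this assay, at which 1 of the 3 values shown sits). Compound 4 `O=c1cc(Nc2ccc(Br)cc2)cc(-c2ccccc2)o1` is not yet measured in this assay. It differs from compound 2 by bromo in place of methyl on an aromatic carbon. For the measured compounds named here, with no step between measured compounds available, the expected step from compound 2 to compound 4 is a 1.7-fold higher number from compound 2 to compound 4 (0.22 log units; within the scatter), at most a small move toward a higher number and possibly none beyond the scatter. For compound 4 the estimate in this assay is 0.15 uM, ranging from 0.04 uM to 0.6 uM.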

Compound 4, concentration for half-maximal effect: 0.4 uM
Beside the measured number, compound 4's estimate is 2.7-fold (0.43 log units) below it; the measured number falls inside the stated range.
By their numbers in this assay, from the lowest: compound 2; then compounds 4 and 1 (each within the scatter of the next). At a limit, above all of these: compound 3.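

In this assay, for the compounds shown here, the step of a 4.4-fold higher number from compound 2 to compound 4 (0.65 log units; beyond the scatter) is the first single-place comparison, and it shows that this place, on an aromatic carbon para to a large group, does not tolerate every exchange without change. The move from 4-methylphenyl to 4-bromophenyl is modest, yet it lies beyond the scatter. No measured property of either group bears on this step.

Open, from the compounds shown here alone, is how an amine, a carboxylic acid or a longer chain at this place would compare with methyl and bromo. Also open, going by these compounds, is whether the same exchange gives a similar step on another core.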